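From 4-methylphenyl to 4-methoxyphenyl in compound 2

The source may hold more compounds than are shown below. What is called first, only, known or untested is meant among the compounds shown, and "the series" means these compounds.

Measured so far in a functional assay on PC-3 cells (Homo sapiens) for antiproliferative activity, read by MTT assay, with a stated time of 72 h; on this read-out lower numbers stand for stronger inhibition and higher numbers for weaker inhibition:
compound 1 `CCOC(=O)c1csc2nc(CN3CCN(C)CC3)c(-c3ccc(Br)cc3)n12` gives 85000 nM 
compound 2 `CCC(=O)NNC(=O)c1csc2ncc(-c3ccc(C)cc3)n12` gives 18500 nM 
compound 3 `CCCC(=O)NNC(=O)c1csc2ncc(-c3ccc(C)cc3)n12` gives 53500 nM 

Of these three, compound 2 stands lowest at 18500 nM in this assay, and the numbers of the other two both lie beyond the scatter from it. Compound 4 `CCC(=O)NNC(=O)c1csc2ncc(-c3ccc(OC)cc3)n12` is still unmeasured. It departs from compound 2 in a single place: methoxy in place of methyl on an aromatic carbon.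

Among the measured compounds shown here, only one measured step is available, a 2.9-fold higher number from compound 2 to compound 3 (0.46 log units; beyond the scatter), which is modest and comes from methyl in place of hydrogen on a saturated chain carbon. That step lies on the chain and not on the aromatic ring, so it bears only loosely on this change and gives a rough sense of how far a small edit can move the number. Compound 1 differs from compound 2 in more than one place and cannot isolate the change. For the measured compounds named here, no measured pair tests a substituent swap on this ring, so no direction can be argued, and no step beyond the scatter is expected in this assay.

The estimated step is a 1.1-fold higher number from compound 2 to compound 4 (0.03 log units; within the scatter), with wide uncertainty. For compound 4 the estimated value is 20000 nM, with an expected range from 8000 nM to 48000 nM.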

Compound 4, half-maximal inhibitory concentration: 79800 nM
Estimate against measurement, compound 4: 4.0-fold (0.60 log units) below, outside the stated range (above it).
By their numbers in this assay, from the lowest: compound 2; then compounds 3, 4 and 1 (each within the scatter of the next).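

In this assay, among the compounds shown here, the aromatic carbon bearing the methyl group of compound 2 turns out to be sensitive to substitution: methoxy in place of methyl gives a 4.3-fold higher number from compound 2 to compound 4 (0.63 log units; beyond the scatter) and is the first measured change on this ring. Together with a 2.9-fold higher number from compound 2 to compound 3 (0.46 log units; beyond the scatter) on the saturated chain, this means that both one-place edits of compound 2 shown here raise the number, one at the ring and one at the chain, and neither edit improves on compound 2 in this assay. The change adds a single oxygen to the substituent, but no supporting data bear on why the number rises.

On these data alone, two measured edits do not define what this position accepts, so it remains open whether a hydroxy group, a fluorine or a plain hydrogen on this aromatic carbon would stay close to compound 2 or move as far as compound 4. As far as these compounds go, it also remains open whether 4-methoxyphenyl would raise the number by a similar step on the longer chain of compound 3, or whether the two edits would combine differently there.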